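This account rests on a few compounds, and the source may have more. Where it says the series, first, only, none or still open, it means among the compounds named here.

Measured compounds:
Compound 1, `C[C@H](N)CN1C[C@H](CCCB(O)O)[C@](N)(C(=O)O)C1`, gives 7.7 nM in an assay for inhibition of arginase-1 (Homo sapiens), read by colorimetric assay, with a stated time of 60 min, in the presence of a further agent that is not named here; on this read-out higher numbers stand for weaker inhibition and lower numbers for stronger inhibition.
Compound 2, `N[C@@]1(C(=O)O)CN(Cc2ccncc2)C[C@@H]1CCCB(O)O`, gives 600 nM in this assay.

Within the data shown here, compound 2 stands at the highest of the two numbers; its nearest neighbour is compound 1, and the only measured step, a 78-fold higher number from compound 1 to compound 2 (1.89 log units; beyond the scatter), shows how much the group on the saturated chain carbon bound to the amine nitrogen in the ring can matter. Compound 3, `Cc1nn(C)c(C)c1CN1C[C@H](CCCB(O)O)[C@](N)(C(=O)O)C1`, differs from compound 2 as follows: 1,3,5-trimethyl-1H-pyrazol-4-yl in place of pyridin-4-yl on a saturated chain carbon bound to an amine nitrogen in a ring. Among the measured compounds shown here, no measured step compares one six-membered aromatic ring against one five-membered aromatic ring at this place, so the one step recorded only shows that exchanges there can be large. Both rings carry hydrogen-bond acceptors and no donors, and neither resembles the 1-aminoethyl of compound 1. A step within or near the scatter is therefore expected, a 1.2-fold lower number from compound 2 to compound 3 (0.08 log units; within the scatter). Compound 3 is estimated at 500 nM, with a range from 150 nM to 2000 nM.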

Compound 3, half-maximal inhibitory concentration: 340 nM
Beside the measured number, compound 3's estimate is 1.5-fold (0.17 log units) above it, within the range that was stated.
By their numbers in this assay, from the lowest: compound 1; then compounds 3 and 2 (each within the scatter of the next).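

In this assay, putting 1,3,5-trimethyl-1H-pyrazol-4-yl in place of pyridin-4-yl on a saturated chain carbon bound to an amine nitrogen in a ring gives a 1.8-fold lower number from compound 2 to compound 3 (0.25 log units; within the scatter), so these two aromatic rings are not told apart here, although they differ in ring size and hetero atoms. The exchange of 1-aminoethyl for the same pyrazole gives a 44-fold higher number from compound 1 to compound 3 (1.64 log units; beyond the scatter), which makes it a second aromatic ring that stands far from compound 1 at this place. Nothing available explains either step.

The compounds shown leave open whether that distance goes with the aromatic ring or with the amine of the 1-aminoethyl. A plain ethyl group, or a phenyl ring carrying an amine, at this place would separate the two.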